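From Cyclopentyl to Cyclohexyl on a Shared Core

The source may report more compounds than this note shows. Statements on the series, on what has been measured and on what is new or still open speak of the compounds shown alone.

compound 1 `O=C(C1CCCC1)N1N=CCC1c1ccccc1`: 1.13 h
compound 2 `CCC(=O)N1CCC(C(=O)N2N=CCC2c2ccccc2)CC1`: > 2.75 h
compound 3 `CC(=O)N1CCC(C(=O)N2N=CC[C@H]2c2ccccc2)CC1`: > 2.75 h

In an ADME assay on microsomes (Homo sapiens) for metabolic stability (a higher number here means that the compound lasts longer, a lower number that the compound disappears faster), compound 1 gives 1.13 h, the only true number among these results. Compound 2 reads > 2.75 h, which is a limit of the assay and not a number. Compound 3 reads > 2.75 h, which is also a limit. The two share one end point: the limit of > 2.75 h in this assay, at which 2 of the 3 values shown sit. Among the compounds with values here, compound 1 is therefore the only compound with an exact half-life, and it falls short of that limit.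

Compound 4 `O=C(C1CCCCC1)N1N=CCC1c1ccccc1` has not yet been measured. It keeps the core of compound 1 and changes one group, with cyclohexyl in place of cyclopentyl on a carbonyl carbon.

Within the data shown here, no measured pair shows a change of this kind, so the starting point is compound 1 at 1.13 h. In this assay the estimated step, a 1.1-fold lower number from compound 1 to compound 4 (0.05 log units; within the scatter), is expected to stay within the usual scatter. The expected value for compound 4 is 1 h, with an estimated range of 0.45 h to 2.2 h.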

Compound 4, half-life: 0.617 h
Compound 4: the middle estimate sits 1.6-fold (0.21 log units) above what was measured; measured number inside the range.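

In this assay, putting cyclohexyl in place of cyclopentyl on a carbonyl carbon gives a 1.8-fold lower number from compound 1 to compound 4 (0.26 log units; within the scatter). This is the first pair shown that differs in one place and has an exact half-life on both sides, so a change at this position can now be read directly, and swapping the five-membered ring of carbon for the six-membered one leaves the two compounds within the usual scatter of each other. Nothing shown bears on why this step has the size it has.

Still open, from the compounds shown here alone, is how this position would respond to a smaller ring such as cyclopropyl, to a longer open carbon chain, or to a group carrying an amine or a carboxylic acid. A single pair also cannot tell whether the same swap would read alike on another core.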